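The source may report more compounds than this note shows. Statements on the series, on what has been measured and on what is new or still open speak of the compounds shown alone.

Measured compounds:
compound 1 `O=C(CN1C(=O)/C(=C/c2ccc(-c3ccc(Cl)cc3)o2)SC1=S)NCc1ccc(F)cc1`, compound 2 `N#Cc1cc(NC(=O)CN2C(=O)/C(=C/c3ccc(-c4ccc(Cl)cc4)o3)SC2=S)ccc1C(F)(F)F`, compound 3 `Cc1ccc(CNC(=O)CN2C(=O)/C(=C/c3ccc(-c4ccc(Cl)cc4)o3)SC2=S)cc1`.

In a functional assay on K562 cells (Homo sapiens) for cytotoxicity, read by MTT assay, with a stated time of 72 h (on this read-out lower numbers stand for stronger inhibition and higher numbers for weaker inhibition), compound 1 gives 150000 nM, and compound 3 gives 45000 nM. For compound 2 the reported value > 250000 nM is a limit of the assay and not a number (the limit of > 250000 nM in this assay, at which 1 of the 3 values shown sits).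

Compound 1 stands at the highest of the two numbers; its nearest neighbour is compound 3, reached by a 3.3-fold lower number from compound 1 to compound 3 (0.52 log units; beyond the scatter). Toward compound 2 the step is an at least 1.6-fold higher number from compound 1 to compound 2 (0.22 log units; that floor lies within the scatter), and between compound 2 and compound 3 it is an at least 5.5-fold lower number from compound 2 to compound 3 (0.74 log units; beyond the scatter).

Compound 4 `O=C(CN1C(=O)/C(=C/c2ccc(-c3ccc(Cl)cc3)o2)SC1=S)NCc1ccc(Br)cc1` differs from compound 1 in one place: bromo in place of fluoro on an aromatic carbon. Within the data shown here, the one measured step that touches the same aromatic carbon is a 3.3-fold lower number from compound 1 to compound 3 (0.52 log units; beyond the scatter), where another group replaced the fluoro. On that basis a modest lowering is expected for compound 4, namely a 2.1-fold lower number from compound 1 to compound 4 (0.33 log units; beyond the scatter). Compound 4 is therefore estimated at 70000 nM in this assay, expected between 25000 nM and 200000 nM.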

Compound 4, half-maximal inhibitory concentration: 68000 nM
Compound 4: the middle estimate sits 1.0-fold (0.01 log units) above what was measured, and the stated range covers the measured number.
By their numbers in this assay, from the lowest: compounds 3 and 4 (each within the scatter of the next); then compound 1. At a limit, above all of these: compound 2.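

Replacing the fluoro of the 4-fluorobenzyl group with bromo also lowers the number in this assay, a 2.2-fold lower number from compound 1 to compound 4 (0.34 log units; beyond the scatter), so this aromatic carbon now has two replacements, methyl and bromo, that each give a lower number than fluoro. These two replacements cannot be ranked, since the step between them stays inside the scatter: a 1.5-fold higher number from compound 3 to compound 4 (0.18 log units; within the scatter). Compound 2 remains a limit and not a number, so its comparison with the new compound gives only a floor, an at least 3.6-fold lower number from compound 2 to compound 4 (0.56 log units; beyond the scatter).

Nothing measured here accounts for why fluoro differs from methyl and bromo at this carbon. Going by these compounds, whether a hydroxyl group, an amine or a carboxylic acid on this same carbon would move the number further remains open.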